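The compounds below may be only part of what the source reports. "The series", "measured", "known", "first", "only" and "open" are said of these compounds alone.

Compound 3 `Fc1ccc(C2=NN(c3ccccc3)C(c3cn(-c4ccccc4)nc3-c3ccc(Cl)c(Cl)c3)C2)cc1` was tested in a functional assay on the whole organism (strain Wistar) for inhibition, with Rattus norvegicus as the target, read by paw edema, with stated times of 30 min and 120 min, at a dose of 50 mg/kg by the oral route (on this read-out higher numbers stand for more inhibition at the one dose given (going by the name of the read-out) and lower numbers for less inhibition), and gives 60.2%. Among the three measured compounds, compound 2 `O=CN1N=C(c2ccc(F)cc2)CC1c1cn(-c2ccccc2)nc1-c1ccc(Cl)c(Cl)c1` gives 60.9%, a number within the scatter of compound 3, while compound 1 `CCC(=O)N1N=C(c2ccc(C)cc2)CC1c1cn(-c2ccccc2)nc1-c1ccc(Cl)c(Cl)c1` gives 70.3%, a gap beyond the scatter. Compound 4 `CCC(=O)N1N=C(c2ccc(F)cc2)CC1c1cn(-c2ccccc2)nc1-c1ccc(Cl)c(Cl)c1` differs from compound 3 in one place: propanoyl in place of phenyl on an amine nitrogen in a ring. For the measured compounds named here, one measured step bears on this change: a number 0.7 percentage points lower from compound 2 to compound 3 (within the scatter), so exchanging formyl for phenyl at that position changed little. Compound 1 also carries propanoyl at this position, and because compound 1 gives 70.3%, a small rise seems plausible. The step expected from compound 3 to compound 4 is a number 4.8 percentage points higher from compound 3 to compound 4 (within the scatter). Compound 4 is therefore estimated at 65%, with a range from 55% to 75%.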

Compound 4, a percentage reported as inhibition, in the whole organism at one dose (the size of the read-out at that dose, not a potency): 75.6%
Beside the measured number, compound 4's estimate is 10.6 percentage points below it, outside the stated range (above it).
By their numbers in this assay, from the lowest: compounds 3, 2, 1 and 4 (each within the scatter of the next, the first and the last beyond it).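

In this assay the group on this ring nitrogen does matter, which the step between formyl and phenyl alone could not show. Propanoyl in place of phenyl gives a number 15.4 percentage points higher from compound 3 to compound 4 (beyond the scatter) while ethyl in place of hydrogen on the carbonyl carbon gives a number 14.7 percentage points higher from compound 2 to compound 4 (beyond the scatter) and so propanoyl stands apart from both phenyl and formyl here. With propanoyl kept, fluoro in place of methyl on the aromatic carbon gives a number 5.3 percentage points higher from compound 1 to compound 4 (within the scatter) and so shows no clear change. As far as these compounds go, whether a longer chain such as butanoyl, or an amine on the acyl chain, would carry this further stays open. Nothing measured here gives a reason for the gain with propanoyl.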